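The compounds below may be only part of what the source reports. "The series", "measured", "known", "first", "only" and "open" are said of these compounds alone.

Measured compounds:
- compound 1, `N=C(N)N/N=C/c1cccc(C(=N)N)c1`: in an assay for inhibition of S-adenosylmethionine decarboxylase proenzyme (Rattus norvegicus) (a lower number here means a stronger inhibitor, a higher number a weaker inhibitor), compound 1 gives 36 nM
- compound 2, `N=C(NO)N/N=C/c1cccc(C(=N)N)c1`: compound 2 gives 92 nM
- compound 3, `N=C(N)N/N=C/c1cccc(C(=N)N)n1`: compound 3 gives 90 nM

Among the compounds with values here, the one measured step is from compound 1 to compound 2, the change (hydroxy in place of hydrogen on an amine nitrogen), which gave a 2.6-fold higher number from compound 1 to compound 2 (0.41 log units; beyond the scatter). Compound 3 differs from compound 1 in its core; that difference between the two cores is not broken down here. The values of compound 2 and compound 3 lie within the scatter of each other.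

Compound 4, `N=C(N)N/N=C/c1cccc(C(=N)NO)n1`, is to be measured in this assay. It stands to compound 3 as compound 2 stands to compound 1: the change (hydroxy in place of hydrogen on an amine nitrogen), the same change at the same kind of place, the amine nitrogen whose other neighbour is a carbon with a double bond to nitrogen. Since this change has been seen once only, the expectation rests on that single step, with the core of compound 3 left as a question. Compound 4 is expected to show a step of about the same size, a 2.6-fold higher number from compound 3 to compound 4 (0.41 log units; beyond the scatter), because the earlier step was a 2.6-fold higher number from compound 1 to compound 2 (0.41 log units; beyond the scatter). The estimate for compound 4 is 230 nM, expected to fall between 120 nM and 450 nM.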

Compound 4, half-maximal inhibitory concentration: 25000 nM
Estimate against measurement, compound 4: 110-fold (2.04 log units) below; measured number above the stated range.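

In this assay, hydroxy in place of hydrogen on an amine nitrogen gave a 280-fold higher number from compound 3 to compound 4 (2.44 log units; beyond the scatter), and the size of the step does not carry over from one core to the other: the same change on two cores in this assay, a 2.6-fold higher number (0.41 log units; beyond the scatter) from compound 1 to compound 2 and a 280-fold higher number (2.44 log units; beyond the scatter) from compound 3 to compound 4, 110-fold (2.04 log units) apart, beyond the scatter of two such steps. The direction is the same in both steps, a weaker inhibitor on each core, but two steps are too few to make this a rule for the series. The source of the gap is not shown: compound 2 and compound 4 differ in their core and also in which amine nitrogen of the molecule carries the hydroxy, so these two differences cannot be separated and neither can be named as the cause.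

Open, going by these compounds, is the step on the core of compound 1 with the hydroxy on the nitrogen that carries it in compound 4, and the step on the core of compound 3 with the hydroxy on the nitrogen that carries it in compound 2. Also open, on these data alone, is how a methoxy or a methyl on these nitrogens would behave on either core.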